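Methoxy in Place of Fluoro on the Pendant Phenyl

The compounds below may be only part of what the source reports. "The series", "measured", "known", "first", "only" and "open" are said of these compounds alone.

Compound 3 `COc1cc(-n2cnc3ccc(-c4cccc(F)c4)cc32)cc(OC)c1OC` gives 5270 nM in a functional assay on A549 cells (Homo sapiens) for antiproliferative activity, read by MTT assay, with a stated time of 72 h (on this read-out higher numbers stand for weaker inhibition and lower numbers for stronger inhibition), the higher of the two numbers shown. Compound 2 `COc1ccc(-c2ccc3ncn(-c4cc(OC)c(OC)c(OC)c4)c3c2)cc1O` gives 200 nM in this assay. Compound 1 `COc1cc(-n2cnc3ccc(-c4ccccc4Cl)cc32)cc(OC)c1OC` reaches only a limit of this assay, > 10000 nM. Compound 4 `COc1cccc(-c2ccc3ncn(-c4cc(OC)c(OC)c(OC)c4)c3c2)c1` differs from compound 3 by methoxy in place of fluoro on an aromatic carbon. Among the measured compounds shown here, two measured steps bear on this site: a 26-fold higher number from compound 2 to compound 3 (1.42 log units; beyond the scatter) was large, whereas an at least 1.8-fold lower number from compound 1 to compound 3 (0.27 log units; that floor lies within the scatter) has a floor within the scatter. For the measured compounds named here, a methoxy alone on this ring has no measured precedent; compound 2 carries it together with a hydroxy. A modest step is therefore expected, a 2.1-fold lower number from compound 3 to compound 4 (0.32 log units; beyond the scatter), toward compound 2 without reaching it. Compound 4 is estimated at 2500 nM, between 800 nM and 8000 nM.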

Compound 4, half-maximal inhibitory concentration: 3180 nM
Compound 4: the middle estimate sits 1.3-fold (0.10 log units) below what was measured; measured number inside the range.
By their numbers in this assay, from the lowest: compound 2; then compounds 4 and 3 (each within the scatter of the next). At a limit, above all of these: compound 1.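

In this assay, methoxy in place of fluoro gives a 1.7-fold lower number from compound 3 to compound 4 (0.22 log units; within the scatter), so this exchange does not separate the two groups at this position. A methoxy alone does not reproduce compound 2 with its 3-hydroxy-4-methoxyphenyl group, as shown by a 16-fold higher number from compound 2 to compound 4 (1.20 log units; beyond the scatter). Against the 2-chlorophenyl group, the 3-methoxyphenyl group gives an at least 3.1-fold lower number from compound 1 to compound 4 (0.49 log units; beyond the scatter), which is only a floor, since compound 1 stands at a limit of the assay: the limit of > 10000 nM in this assay, at which 1 of the 4 values shown sits.

As far as these compounds go, whether a 3-hydroxyphenyl group alone would match compound 2 stays open. So does what an amine or a carboxylic acid would give at this place.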